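The source may report more compounds than this note shows. Statements on the series, on what has been measured and on what is new or still open speak of the compounds shown alone.

Measured compounds:
compound 1 `C/C(C(=O)NC1CC1)=C(/C)c1ccc(F)cc1`, 110 mg/kg
compound 2 `C/C(C(=O)NC1CC1)=C(\C)c1ccccc1`, 400 mg/kg
compound 3 `C#CCNC(=O)/C(C)=C(\C)c1ccccc1`, 150 mg/kg

Of the compounds shown here, three have been tested in a toxicity assay on the whole organism (strain Icem-CET (SPF Caw)) for cytotoxicity, with Mus musculus as the target; a lower number here means that less compound is needed, a higher number that more compound is needed for the effect. Compound 3 stands second highest of the three numbers. Its nearest neighbour is compound 1, whose number is a little lower, a gap that lies within the usual scatter of repeated measurements. Compound 2 is the furthest away, with a clearly higher number, a gap beyond the scatter.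

Compound 4 `C/C(C(=O)NC1CC1)=C(/C)c1ccccc1` has not yet been measured. It differs from compound 3 in one place: cyclopropyl in place of propargyl on an amide-type nitrogen. Compound 1 and compound 2 already carry a cyclopropyl on the amide-type nitrogen, and in this assay compound 1 gives 110 mg/kg while compound 2 gives 400 mg/kg. Those two numbers bracket the value of compound 3, so no clear direction can be read from them for a cyclopropyl in place of a propargyl.

For compound 4 a small step upward from compound 3 is expected, a 1.2-fold higher number from compound 3 to compound 4 (0.08 log units; within the scatter), most likely within the scatter and in either direction. The estimate for compound 4 in this assay is 180 mg/kg, with a range from 80 mg/kg to 450 mg/kg.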

Compound 4, dose for half-maximal effect: 100 mg/kg
Beside the measured number, compound 4's estimate is 1.8-fold (0.26 log units) above it; the range from low to high includes it.
By their numbers in this assay, from the lowest: compounds 4, 1 and 3 (each within the scatter of the next); then compound 2.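

In this assay, cyclopropyl in place of propargyl on the amide-type nitrogen gives a 1.5-fold lower number from compound 3 to compound 4 (0.18 log units; within the scatter), so these two groups cannot be told apart at this position in this assay. Hydrogen in place of fluoro on an aromatic carbon gives a 1.1-fold lower number from compound 1 to compound 4 (0.04 log units; within the scatter), so that change cannot be told apart from the scatter either, and the spread between compounds 1 and 2, which gave no clear direction for cyclopropyl, is not a matter of the fluoro group alone. The one step here beyond the scatter is a 4.0-fold lower number from compound 2 to compound 4 (0.60 log units; beyond the scatter), and it can be tied to the double bond, drawn Z in compound 2 and E in compound 4, because of one fact: the fact that compounds 2 and 4 differ only in the configuration as drawn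

As far as these compounds go, the link between double-bond geometry and the number in this assay rests on this single pair, so it remains open whether the same gap would appear with propargyl or with the fluoro group in place. Also open, from the compounds shown here alone, is how the number would respond to other groups on the amide-type nitrogen, such as a methyl group, a longer carbon chain or a chain ending in an amine.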